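This account rests on a few compounds, and the source may have more. Where it says the series, first, only, none or still open, it means among the compounds named here.

Measured so far in a functional assay on the whole organism with Mus musculus as the target; on this read-out lower numbers stand for an effect already at smaller amounts and higher numbers for an effect only at larger amounts of compound:
- compound 1 `CCCCC(C)NCC(N)=O`: 640 mg/kg
- compound 2 `CN(CC(N)=O)Cc1ccc(OCc2cccc(Cl)c2)cc1`: 114 mg/kg
- compound 3 `C[C@@H](NCc1ccc(OCc2ccccc2)cc1)C(N)=O`: 23.8 mg/kg

Compound 3 has the lowest number of the three. Its gaps to compound 2 and to compound 1 both lie beyond the scatter, and compound 1 is the furthest away.

The next compound is compound 4 `CNC(=O)[C@@H](C)NCc1ccc(OCc2ccccc2)cc1`. It keeps the core of compound 3 and carries methyl in place of hydrogen on an amide-type nitrogen, turning carbamoyl into methylcarbamoyl: methyl in place of hydrogen on an amide-type nitrogen.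

Among the compounds with values here, no pair of measured compounds differs in one place only, so the series gives no direct precedent for this change. With so little to go on, a small step towards a higher number is expected in this assay, of about the size of the scatter, and a larger loss cannot be ruled out. The estimate amounts to an expected 1.7-fold higher number from compound 3 to compound 4 (0.23 log units; within the scatter). The expected value for compound 4 is 40 mg/kg, with an estimated range of 15 mg/kg to 120 mg/kg.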

Compound 4, dose for half-maximal effect: 40.5 mg/kg
Compound 4: middle estimate off by 1.0-fold (0.01 log units), on the low side, and the stated range covers the measured number.
By their numbers in this assay, from the lowest: compounds 3 and 4 (each within the scatter of the next); then compound 2; then compound 1.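

Within the data shown here, the change reads in this assay as a 1.7-fold higher number from compound 3 to compound 4 (0.23 log units; within the scatter) and is the first step that differs in one place only. At this position, methylcarbamoyl in compound 4 therefore stands within the scatter of carbamoyl in compound 3, so losing one amide hydrogen to a single added carbon leaves the number in the same range. No measurement in hand gives a reason for this result.

Still open, from the compounds shown here alone, is whether the position holds up with more than one carbon, such as ethyl or a longer chain on the amide-type nitrogen, or with a second methyl replacing the remaining amide hydrogen. Also open, going by these compounds, is how a carboxylic acid or a methyl ester would read in place of the carbamoyl group.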